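From compound 3 to compound 4: a much smaller group

The compounds below may be only part of what the source reports. "The series", "measured", "known", "first", "only" and "open" are said of these compounds alone.

In a functional assay on HCT-116 cells (Homo sapiens) for antiproliferative activity, read by MTT assay, with a stated time of 72 h (a higher number here means a weaker inhibitor, a lower number a stronger inhibitor), compound 3 `O=C1O[C@H]([C@@H](O)Cn2cc(CNS(=O)(=O)c3ccc(Cl)cc3)nn2)C(OCc2ccccc2)=C1OCc1ccccc1` gives 8380 nM, level within the scatter with compound 1 `O=C1O[C@H]([C@@H](O)Cn2cc(-c3ccc(Br)cc3)nn2)C(OCc2ccccc2)=C1OCc1ccccc1` at 9420 nM, while compound 2 `CCCCCCCCCCc1cn(C[C@H](O)[C@H]2OC(=O)C(OCc3ccccc3)=C2OCc2ccccc2)nn1` gives 28800 nM. Compound 4 `O=C1O[C@H]([C@@H](O)Cn2cc(CCO)nn2)C(OCc2ccccc2)=C1OCc1ccccc1` differs from compound 3 in one place: hydroxymethyl in place of ((4-chlorophenyl)sulfonyl)amino on a saturated chain carbon bound to an aromatic carbon. Hydroxymethyl stands in place of ((4-chlorophenyl)sulfonyl)amino, on a saturated chain carbon bound to an aromatic carbon. Three measured changes at this position bear on it. Swapping one ring-bearing group for another gave a 1.1-fold lower number from compound 1 to compound 3 (0.05 log units; within the scatter), inside the scatter. Compound 2 has no ring in that group, and it gave a 3.1-fold higher number from compound 1 to compound 2 (0.49 log units; beyond the scatter) and a 3.4-fold lower number from compound 2 to compound 3 (0.54 log units; beyond the scatter), both modest. Compound 4 also lacks that ring, so a modest rise is expected in this assay, a 2.4-fold higher number from compound 3 to compound 4 (0.38 log units; beyond the scatter). The estimate for compound 4 is 20000 nM, with an expected range of 8000 nM to 60000 nM.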

Compound 4, half-maximal inhibitory concentration: 72700 nM
The estimate for compound 4 lay 3.6-fold (0.56 log units) below the measured number; the whole stated range lies below it.
By their numbers in this assay, from the lowest: compounds 3 and 1 (each within the scatter of the next); then compound 2; then compound 4.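

In this assay, 2-hydroxyethyl gives the highest number of the four compounds, with an 8.7-fold higher number from compound 3 to compound 4 (0.94 log units; beyond the scatter), a 7.7-fold higher number from compound 1 to compound 4 (0.89 log units; beyond the scatter) and a 2.5-fold higher number from compound 2 to compound 4 (0.40 log units; beyond the scatter). Losing the ring therefore does not set the outcome alone: compound 2 and compound 4 both lack it, yet the decyl group of compound 2 keeps the lower number. No measurement here explains this step. The compounds shown leave open whether the hydroxy group or the short chain matters more. A plain butyl chain or a 2-aminoethyl group would help separate the two.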